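A Trimethoxyphenyl Swap on the Analogue with the Highest Number

A few compounds are considered here, and "the series" means these few. Any claim that something is new, unique, unknown or untested is made for them only; others in the source may bear on it.

Of the compounds shown here, three of a shared core have been tested in a functional assay on the whole organism (strain Swiss albino) with Mus musculus as the target, in the forced swim test, with a stated time of 5 min, at a dose of 0.5 mg/kg by the intraperitoneal route; a lower number here means less inhibition, a higher number more inhibition at the dose given (going by the name of the read-out). Compound 1 `COc1ccc(-c2cc3cc(C4C(C#N)=C(N)OC5=C4C(=O)CC(C)(C)C5)cc(C)c3oc2=O)cc1OC` gives 10.4%, and compound 2 `COc1cc(-c2cc3cc(C4C(C#N)=C(N)OC5=C4C(=O)CCC5)cc(C)c3oc2=O)cc(OC)c1OC` gives 5.22%. Compound 3 `COc1ccc(-c2cc3cc(C4C(C#N)=C(N)OC5=C4C(=O)CCC5)cc(C(C)C)c3oc2=O)cc1` stands highest of the three, with 69.7%; its gap to compound 1 and to compound 2 lies beyond the scatter in both cases, so compound 3 has the highest inhibition in this assay of the measured set.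

Compound 4 `COc1cc(-c2cc3cc(C4C(C#N)=C(N)OC5=C4C(=O)CCC5)cc(C(C)C)c3oc2=O)cc(OC)c1OC` is not yet measured. It differs from compound 3 in one place: 3,4,5-trimethoxyphenyl in place of 4-methoxyphenyl on an aromatic carbon. Within the data shown here, compound 2 already carries the 3,4,5-trimethoxyphenyl group, but it also differs from compound 3 in another group, so no single step isolates this change. Among the measured compounds shown here, with only that indirect comparison, a drop is expected from compound 3 to compound 4 in this assay, sized at a number 34.7 percentage points lower from compound 3 to compound 4 (beyond the scatter), though the uncertainty is large. Compound 4 is therefore estimated at 35%, within a range from 5% to 70%.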

Compound 4, a percentage reported as inhibition, in the whole organism at one dose (the size of the read-out at that dose, not a potency): 31.9%
Compound 4: middle estimate off by 3.1 percentage points, on the high side; the measured number falls inside the stated range.
By their numbers in this assay, from the lowest: compounds 2 and 1 (each within the scatter of the next); then compound 4; then compound 3.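

In this assay, putting 3,4,5-trimethoxyphenyl in place of 4-methoxyphenyl gives a number 37.8 percentage points lower from compound 3 to compound 4 (beyond the scatter), so this change can now be read on its own, with the isopropyl group held constant. The new compound also isolates a second change: with 3,4,5-trimethoxyphenyl held constant, isopropyl in place of methyl gives a number 26.7 percentage points higher from compound 2 to compound 4 (beyond the scatter), so each of the two groups matters on its own in this pair. No measurement here explains why either step occurs.

From the compounds shown here alone, it remains open whether fewer methoxy groups on that phenyl ring would give a smaller drop, or how a hydroxyl group or a chlorine atom there would compare. Also open, going by these compounds, is how an ethyl group or a longer chain would compare with isopropyl, and a read-out at a single dose says nothing about potency.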